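A few compounds are considered here, and "the series" means these few. Any claim that something is new, unique, unknown or untested is made for them only; others in the source may bear on it.

Measured so far:
compound 1, `CCCCCCCCCCCCCC[C@H](O)[C@H](CO[Si](c1ccccc1)(c1ccccc1)C(C)(C)C)NC(=O)OC(C)(C)C`, in a functional assay on NCI-H358 cells (Homo sapiens) for antiproliferative activity, read by sulforhodamine B assay, with a stated time of 48 h, tested at 10 uM (a higher number here means more inhibition at the concentration tested (going by the name of the read-out), a lower number less inhibition), gives 3.11%;
compound 2, `CCCCCCCCCCCCCC[C@H](OCOC)[C@H](CN(CC)CC)NC(=O)OC(C)(C)C`, in this assay gives 15%.

Of the two compounds with numbers, compound 2 stands highest in this assay, and its gap to compound 1 lies beyond the usual scatter of this kind of measurement. Going by the values given here, no pair of measured compounds differs in only one place, so no single step has yet been seen.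

Compound 3, `CCCCCCCCCCCCCC[C@H](OCOC)[C@H](CN(CCCC)CCCC)NC(=O)OC(C)(C)C`, has not been measured. It differs from compound 2 in one place: dibutylamino in place of diethylamino on a saturated chain carbon, two bonds along the chain from an amide-type nitrogen. The change exchanges diethylamino for dibutylamino on a saturated chain carbon, two bonds along the chain from an amide-type nitrogen, and nothing else in the shared core moves.

Among the compounds with values here, with no comparable step to lean on, the expected step of a number 7 percentage points higher from compound 2 to compound 3 (within the scatter) from compound 2 is small and upward, likely close to the scatter. For compound 3 the estimate in this assay is 22%, in a range from 5% to 45%.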

Compound 3, a percentage reported as inhibition, at one concentration (the size of the read-out at that concentration, not a potency): 25.1%
The estimate for compound 3 lay 3.1 percentage points below the measured number; measured number inside the range.
By their numbers in this assay, from the lowest: compound 1; then compound 2; then compound 3.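

Exchanging diethylamino for dibutylamino on a saturated chain carbon, two bonds along the chain from an amide-type nitrogen, gives a number 10.1 percentage points higher from compound 2 to compound 3 (beyond the scatter) in this assay. Going by these compounds alone, this is the first single change seen, and it shows that the read-out responds to the groups on this amine, with the change from 5 to 9 heavy atoms going with more inhibition at the concentration tested. No measurement at hand accounts for this step, which rests on this one pair alone.

The compounds shown leave open whether a longer chain on this nitrogen, such as dihexylamino, would raise the number further, or whether a ring amine such as piperidine or morpholine would do the same. They also leave open what a free hydroxyl in place of the methoxymethyl ether would do with the dibutylamino group in place.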